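A bigger group on compound 2's oxygen

A few compounds are considered here, and "the series" means these few. Any claim that something is new, unique, unknown or untested is made for them only; others in the source may bear on it.

In an ADME assay on BJ cells (Homo sapiens) for cytotoxicity, read by CellTiter-Glo, with a stated time of 72 h (on this read-out higher numbers stand for an effect only at larger amounts of compound and lower numbers for an effect already at smaller amounts), compound 1 `CC1=C2CC(C)(C)/C=C/C/C(C)=C\C3=C[C@H](C)C[C@]3(O2)C1=O` gives 26000 nM and compound 2 `CC(=O)O[C@H]1/C=C/C(C)(C)CC2=C(C)C(=O)[C@]3(C[C@@H](C)C=C3/C=C\1C)O2` gives 26000 nM, so compound 2 stands level with compound 1. Compound 3 `CC1=C2CC(C)(C)/C=C/[C@H](OC(=S)n3ccnc3)/C(C)=C\C3=C[C@H](C)C[C@]3(O2)C1=O` differs from compound 2 on an oxygen on a saturated carbon: a group of 7 heavy atoms (4 carbon, 2 nitrogen, 1 sulfur; one five-membered aromatic ring with 2 hetero atoms) in place of a group of 3 heavy atoms (2 carbon, 1 oxygen; no ring), on an oxygen on a saturated carbon. Among the compounds with values here, only one measured step bears on this, no change at the digits printed from compound 1 to compound 2 (within the scatter), where an acetoxy took the place of hydrogen on a saturated ring carbon. It is a single step with a much smaller group, so it is weak guidance. The expected change is a 1.4-fold lower number from compound 2 to compound 3 (0.16 log units; within the scatter), with no step beyond the scatter and a slight lean towards smaller amounts. For compound 3 the estimated value in this assay is 18000 nM, with an expected range of 6000 nM to 35000 nM.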

Compound 3, half-maximal effective concentration: 26000 nM
Estimate against measurement, compound 3: 1.4-fold (0.16 log units) below; low and high end bracket the measured number.
By their numbers in this assay, from the lowest: compounds 1, 2 and 3 (each within the scatter of the next).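

In this assay, the larger group with its five-membered aromatic ring replaces the acetyl on the oxygen, and the result is no change at the digits printed from compound 2 to compound 3 (within the scatter). Set against hydrogen, the whole new group gives no change at the digits printed from compound 1 to compound 3 (within the scatter), so this saturated ring carbon has now carried two very different groups with no step beyond the scatter. Nothing available explains this result.

From the compounds shown here alone, whether an amine or a carboxylic acid at this position would also leave the number in place remains open. So does whether a free hydroxyl there would.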